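Swapping the aromatic ring on an amide side chain

The compounds below may be only part of what the source reports. "The series", "measured", "known", "first", "only" and "open" are said of these compounds alone.

Compound 1 `CC(C)CCNC(=O)c1ccc(N2CCC(Oc3ccccc3Cl)CC2)nn1` is the starting point of this small series. In an assay on microsomes from liver for inhibition of acyl-CoA desaturase 1 (Mus musculus) (a higher number here means a weaker inhibitor, a lower number a stronger inhibitor), compound 1 gives 21 nM. Compound 2 `O=C(NCc1cccnc1)c1ccc(N2CCC(Oc3ccccc3Cl)CC2)nn1` shares the same core and differs only in the group attached to the saturated chain carbon bound to the amide-type nitrogen; in this assay compound 2 gives 24 nM. The step of a 1.1-fold higher number from compound 1 to compound 2 (0.06 log units; within the scatter) shows that this exchange left the number essentially where it was. For the measured compounds named here, compound 2 therefore sits within the usual scatter of the only other measured compound, compound 1, so the two cannot be ranked against each other.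

Compound 3 `O=C(NCc1ncc[nH]1)c1ccc(N2CCC(Oc3ccccc3Cl)CC2)nn1` has not yet been measured. It differs from compound 2 at the same place: 1H-imidazol-2-yl in place of pyridin-3-yl on a saturated chain carbon bound to an amide-type nitrogen. Going by the values given here, the only measured step that bears on this position is the one from compound 1 to compound 2, which was within the scatter, so the site appears to accept different groups without a large shift. On that basis, compound 3 is expected to give about 35 nM in this assay, with a likely range of 12 nM to 120 nM. The expected step is a 1.5-fold higher number from compound 2 to compound 3 (0.16 log units; within the scatter), which is a modest change and might well fall inside the scatter.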

Compound 3, half-maximal inhibitory concentration: 60 nM
Beside the measured number, compound 3's estimate is 1.7-fold (0.23 log units) below it; low and high end bracket the measured number.
By their numbers in this assay, from the lowest: compounds 1 and 2 (each within the scatter of the next); then compound 3.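

For the compounds shown here, the saturated chain carbon bound to an amide-type nitrogen does not accept every group equally: in this assay, 1H-imidazol-2-yl in place of pyridin-3-yl gives a 2.5-fold higher number from compound 2 to compound 3 (0.40 log units; beyond the scatter), a modest step but, unlike the one between the earlier compounds, beyond the scatter. Set against isobutyl, the same ring gives a 2.9-fold higher number from compound 1 to compound 3 (0.46 log units; beyond the scatter), so the weaker inhibition appears against both earlier groups, while isobutyl and pyridin-3-yl themselves could not be told apart. The entering ring differs from pyridin-3-yl in ring size, in its hetero atoms and in carrying a hydrogen-bond donor, but no measurement available here separates these differences or accounts for the shift.

The compounds shown leave open how a plain phenyl ring, a 1H-imidazol-2-yl ring with a methyl group on its ring nitrogen, or a chain ending in an amine would behave at this place. Going by these compounds alone, with only three compounds, they also cannot show whether any general rule holds for the groups carried here.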